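Propyl on the oxygen of compound 3

The source may report more compounds than this note shows. Statements on the series, on what has been measured and on what is new or still open speak of the compounds shown alone.

Going by the values given here, in a functional assay on the whole organism (strain Sprague-Dawley) for inhibition, with Rattus norvegicus as the target, with a stated time of 10 min (a higher number here means that more compound is needed for the effect, a lower number that less compound is needed), compound 3 `CCOC(=O)c1cnc(-c2ccccc2O)[nH]c1=O` gives 5 mg/kg, level with compound 2 `CCOC(=O)c1cnc(-c2ccccc2Cl)[nH]c1=O` at 5 mg/kg, and these two share the highest number so far. Compound 4 `CCCOc1ccccc1-c1ncc(C(=O)OCC)c(=O)[nH]1` differs from compound 3 by propyl in place of hydrogen on an oxygen on an aromatic ring, which reads as hydroxy to propoxy. Among the compounds with values here, the only measured step at this place, hydroxy in place of chloro, shows no change at the digits printed from compound 2 to compound 3 (within the scatter), so it offers no sign of a large shift. Compound 1 `CCCOc1ccccc1-c1ncc(C(=O)O)c(=O)[nH]1` carries propoxy too and gives a lower 0.9 mg/kg, but it holds an acid instead of the ethyl ester, so the two changes cannot be separated. A modest fall is therefore expected, an estimated 2.0-fold lower number from compound 3 to compound 4 (0.30 log units; within the scatter). For compound 4 the estimate is 2.5 mg/kg, with an expected range of 0.8 mg/kg to 7 mg/kg.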

Compound 4, dose for 50% inhibition: 5 mg/kg
Compound 4: the middle estimate sits 2.0-fold (0.30 log units) below what was measured; measured number inside the range.
By their numbers in this assay, from the lowest: compound 1; then compounds 2, 3 and 4 (each within the scatter of the next).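

In this assay, the step from hydroxy to propoxy with the ethyl ester held (no change at the digits printed from compound 3 to compound 4 (within the scatter)) and the step from chloro to propoxy (no change at the digits printed from compound 2 to compound 4 (within the scatter)) leave chloro, hydroxy and propoxy at this place not told apart. The ethyl in place of hydrogen on an oxygen next to a carbonyl group (a 5.6-fold higher number from compound 1 to compound 4 (0.74 log units; beyond the scatter)) now separates the two changes that compound 1 had joined, and this step lies beyond the scatter. Nothing on hand gives a reason for either result.

As far as these compounds go, whether a chain longer than propyl or an amine at this place would shift the number stays open. So does whether the carboxylic acid keeps its lower number with chloro or hydroxy in place of propoxy.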